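A benzothiazole pair and an untested pyridine analogue

A few compounds are considered here, and "the series" means these few. Any claim that something is new, unique, unknown or untested is made for them only; others in the source may bear on it.

Of the compounds shown here, two of a shared core have been tested so far. Compound 1 `CN(C)c1ccc2sc(-c3c(Cl)nc(N)nc3N[C@@H]3C[C@H](CO)[C@@H](O)[C@H]3O)nc2c1` carries an amino group and a chlorine on its core; in an ADME assay on cells (Homo sapiens) for cytotoxicity, read by polymerase chain reaction, with a stated time of 3 days (on this read-out lower numbers stand for higher toxicity in this test and higher numbers for lower toxicity in this test), compound 1 gives 25000 nM. Compound 2 `Cc1nc(NCCOC(C)C)nc(N[C@@H]2C[C@H](CO)[C@@H](O)[C@H]2O)c1-c1nc2ccccc2s1` carries a methyl group and a 2-isopropoxyethylamino side chain; in this assay compound 2 gives 8000 nM. Of the two numbers shown, compound 2 stands lowest, so it is the more toxic of the pair, and the gap to compound 1 lies beyond the usual scatter.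

Compound 3 `Cc1nc(NCc2ccncc2)nc(N[C@@H]2C[C@H](CO)[C@@H](O)[C@H]2O)c1-c1nc2ccccc2s1` is not yet measured. It differs from compound 2 in one place: pyridin-4-yl in place of isopropoxymethyl on a saturated chain carbon bound to a nitrogen on an aromatic ring. Among the compounds with values here, no measured step of this kind exists here to lean on. The expected step from compound 2 to compound 3 is a 1.1-fold higher number from compound 2 to compound 3 (0.05 log units; within the scatter), a change not beyond the scatter, because compound 2 gives 8000 nM and the side chain is only exchanged, not removed. Compound 3 is therefore estimated at 9000 nM, with a range from 3000 nM to 27000 nM.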

Compound 3, half-maximal cytotoxic concentration: 7000 nM
Compound 3: the middle estimate sits 1.3-fold (0.11 log units) above what was measured; low and high end bracket the measured number.
By their numbers in this assay, from the lowest: compounds 3 and 2 (each within the scatter of the next); then compound 1.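

In this assay, putting pyridin-4-yl in place of isopropoxymethyl on a saturated chain carbon bound to a nitrogen on an aromatic ring gives a 1.1-fold lower number from compound 2 to compound 3 (0.06 log units; within the scatter) and stays within the usual scatter. This is the only comparison shown that isolates a single place, and it shows that an aromatic ring and an open ether chain at this position read alike in this test. Nothing measured here says why the two compounds match.

Going by these compounds, whether that match extends to other groups at this place stays open, for example a chain ending in an amine, a carboxylic acid or a longer chain. Compound 1 differs from compound 2 in more than one place, so the gap between them cannot be assigned to any one group.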